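Thiazole acetic acids at the prostaglandin D2 receptor 2

A few compounds are considered here, and "the series" means these few. Any claim that something is new, unique, unknown or untested is made for them only; others in the source may bear on it.

Measured compounds:
compound 1 `NS(=O)(=O)c1ccc(-c2nc(C(c3ccc(F)cc3)c3ccc(F)cc3)sc2CC(=O)O)cc1`: 1500 nM
compound 2 `O=C(O)Cc1sc(C(c2ccccc2)c2ccc(F)c(F)c2)nc1-c1ccc(F)cc1`: 10 nM
compound 3 `O=C(O)Cc1sc(C(c2ccccc2)c2ccc(O)cc2)nc1-c1ccc(F)cc1`: 3.4 nM

In an in vitro assay on HEK385-7 cells for displacement of a labelled ligand from prostaglandin D2 receptor 2 (Homo sapiens) (a higher number here means a weaker inhibitor, a lower number a stronger inhibitor), compound 1 gives 1500 nM and stands highest of the three numbers; the nearest is compound 2 with 10 nM, the furthest compound 3 with 3.4 nM. Among the measured compounds shown here, the one measured step, a 2.9-fold lower number from compound 2 to compound 3 (0.47 log units; beyond the scatter), concerns the saturated chain carbon bound to two aromatic carbons and says nothing about the aromatic carbon of the shared core.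

Compound 4 `Cc1cc(-c2nc(C(c3ccc(F)cc3)c3ccc(F)cc3)sc2CC(=O)O)ccn1` differs from compound 1 by 2-methylpyridin-4-yl in place of 4-sulfamoylphenyl on an aromatic carbon. No measured step bears on this change, so the direction rests on no shown data. Compound 4 is expected to give 400 nM (range 80 nM to 2500 nM), an estimated step of a 3.8-fold lower number from compound 1 to compound 4 (0.57 log units; beyond the scatter).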

Compound 4, half-maximal inhibitory concentration: 3.1 nM
The estimate for compound 4 lay 130-fold (2.11 log units) above the measured number; the whole stated range lies above it.
By their numbers in this assay, from the lowest: compounds 4 and 3 (each within the scatter of the next); then compound 2; then compound 1.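

The aromatic carbon of the shared core that bears the carboxymethyl group's neighbouring aryl substituent, which the earlier step did not touch, responds strongly in this assay: 2-methylpyridin-4-yl in place of 4-sulfamoylphenyl gives a 480-fold lower number from compound 1 to compound 4 (2.68 log units; beyond the scatter) on the same background. That step is far larger than the only other one available, a 2.9-fold lower number from compound 2 to compound 3 (0.47 log units; beyond the scatter), at the saturated chain carbon. Nothing shown here explains the size of this step.

Open, from the compounds shown here alone, is whether the gain follows the entering group or the departure of the sulfamoyl group. A plain pyridin-4-yl or a 4-methylphenyl on the same carbon would separate the ring nitrogen from the methyl.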